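A Swap on an Amide-Type Nitrogen

This account rests on a few compounds, and the source may have more. Where it says the series, first, only, none or still open, it means among the compounds named here.

Of the compounds shown here, two sharing one core have been measured so far. In a functional assay on A549 cells (Homo sapiens) for antiproliferative activity, read by MTT assay (on this read-out higher numbers stand for weaker inhibition and lower numbers for stronger inhibition), compound 1 `COc1cc2c(Oc3ccc(NC(=O)Nc4ccc(Cl)c(C(F)(F)F)c4)cc3)ccnc2cc1OCCCCCCC(=O)NO` gives 5020 nM and compound 2 `COc1cc2c(Oc3ccc(NC(=O)N/N=C/c4ccccc4)cc3)ccnc2cc1OCCCCCCC(=O)NO` gives 3700 nM so compound 2 stands level with compound 1 within the usual scatter.

The unmeasured compound 3 `COc1cc2c(Oc3ccc(NC(=O)NNC(=O)c4ccccc4F)cc3)ccnc2cc1OCCCCCCC(=O)NO` differs from compound 2 in one place: a group of 10 heavy atoms (7 carbon, 1 nitrogen, 1 oxygen, 1 fluorine; one six-membered aromatic ring of carbon only) in place of a group of 8 heavy atoms (7 carbon, 1 nitrogen; one six-membered aromatic ring of carbon only), on an amide-type nitrogen and the entering group is called ((2-fluorophenyl)carbonyl)amino.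

Within the data shown here, only one measured step bears on this change: a 1.4-fold lower number from compound 1 to compound 2 (0.13 log units; within the scatter) which also exchanged a group on an amide-type nitrogen and stayed within the scatter. A single step is thin evidence, but it gives no reason to expect a shift beyond the scatter in this assay for this swap. The expected change is a 1.0-fold higher number from compound 2 to compound 3 (0.01 log units; within the scatter) with neither direction favoured. For compound 3 the estimated value is 3800 nM (expected range 1500 nM to 9500 nM).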

Compound 3, half-maximal inhibitory concentration: 2420 nM
Compound 3: the middle estimate sits 1.6-fold (0.20 log units) above what was measured; measured number inside the range.
By their numbers in this assay, from the lowest: compounds 3, 2 and 1 (each within the scatter of the next, the first and the last beyond it).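

In this assay, the step shows that this amide-type nitrogen also tolerates ((2-fluorophenyl)carbonyl)amino, a group that brings a hydrogen-bond donor the leaving group lacks: a 1.5-fold lower number from compound 2 to compound 3 (0.18 log units; within the scatter) stays inside the usual scatter. Set against the 4-chloro-3-(trifluoromethyl)phenyl group, the same entering group gives a 2.1-fold lower number from compound 1 to compound 3 (0.32 log units; beyond the scatter) and so provides the first step at this position to pass the scatter, though only modestly. No outside measurement is available to explain either step.

As far as these compounds go, the fluorine's share remains open, since a plain benzoylamino group or a (2-chlorophenyl)carbonylamino group on the same nitrogen would separate it from the rest of the entering group. From the compounds shown here alone, it is also open whether a simple amine or a small alkyl chain at this nitrogen would keep numbers of this size.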